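The source may hold more compounds than are shown below. What is called first, only, known or untested is meant among the compounds shown, and "the series" means these compounds.

Two compounds of this set have numbers in an assay on cells for inhibition of MAP kinase-interacting serine/threonine-protein kinase 1 (Homo sapiens), read by mobility shift assay, with stated times of 10 min and 60 min, in the presence of a further agent that is not named here (a higher number here means a weaker inhibitor, a lower number a stronger inhibitor), so far. Compound 1 `CC(C)Oc1cc(-c2cncc(-c3c[nH]nc3C3CC3)c2)ccc1C(N)=O` gives 130 nM in this assay. Compound 2 `NC(=O)c1ccc(-c2cccnc2)cc1Cl`, a much smaller molecule, gives 11000 nM in this assay, the highest of the two numbers and far from compound 1, well beyond the scatter. Compound 3 `Cc1cc(-c2cccnc2)ccc1C(N)=O` has not yet been measured. It differs from compound 2 in one place: methyl in place of chloro on an aromatic carbon. Chloro and methyl each count one heavy atom, carry no donor or acceptor and no charge, and sit on the same aromatic carbon of the ring of carbon only, ortho to the carbamoyl group. Among the compounds with values here, no pair of measured compounds shows the effect of such a swap, so the step from compound 2 to compound 3 is expected to be a 1.1-fold higher number from compound 2 to compound 3 (0.04 log units; within the scatter), that is no change beyond the scatter. Compound 3 is therefore estimated at 12000 nM in this assay, within a range of 5000 nM to 30000 nM.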

Compound 3, half-maximal inhibitory concentration: 22000 nM
For compound 3 the middle estimate is 1.8-fold (0.26 log units) below the measured one; the measured number falls inside the stated range.
By their numbers in this assay, from the lowest: compound 1; then compounds 2 and 3 (each within the scatter of the next).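

In this assay, putting methyl in place of chloro on the aromatic carbon ortho to a carbamoyl group gives a 2.0-fold higher number from compound 2 to compound 3 (0.30 log units; within the scatter) and so does not separate the two groups at this position. Within the data shown here, this is the first step in the set that can be read at a single place, and it shows that exchanging these two groups, each of one heavy atom with no hydrogen-bond donor or acceptor, leaves the number within the scatter on this small scaffold. Nothing measured here bears on the reason for this result.

On these data alone, it remains open whether a methoxy group, an amine or a plain hydrogen on the same aromatic carbon would also stay within the scatter of these two compounds. As far as these compounds go, it is also open whether chloro and methyl would stay as close on the larger core of compound 1.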